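Removing one methoxy from compound 2

This account rests on a few compounds, and the source may have more. Where it says the series, first, only, none or still open, it means among the compounds named here.

Compound 1 `COc1cc(OC)c(OC)cc1/C=C/COC(=O)/C=C/c1ccc(OC)c(OC)c1` gives 93.3 mg/kg
Compound 2 `COc1cc(OC)c(OC)cc1/C=C/COC(=O)/C=C/c1cc(OC)c(OC)c(OC)c1OC` gives 42.2 mg/kg

Both values come from a functional assay on the whole organism (strain Kunming) with Mus musculus as the target, in the formalin test, with a stated time of 0.5 h; a higher number here means that more compound is needed for the effect, a lower number that less compound is needed. Compound 2 stands at 42.2 mg/kg, the lower of the two numbers, so less of it is needed for the effect. Compound 1 has the higher number, and the gap between the two lies beyond the usual scatter.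

Compound 3 `COc1cc(OC)c(OC)cc1/C=C/COC(=O)/C=C/c1cc(OC)c(OC)c(OC)c1` has not yet been measured in this assay. It departs from compound 2 by one change, hydrogen in place of methoxy on an aromatic carbon. Within the data shown here, no measured pair shows this exact change, so the expectation is tentative. It rests only on the two known values, compound 2 at 42.2 mg/kg and compound 1 at 93.3 mg/kg. A modest move towards a higher number is expected, most likely not beyond the scatter, and the estimated change is a 1.4-fold higher number from compound 2 to compound 3 (0.14 log units; within the scatter). The estimate for compound 3 is 58 mg/kg, with an expected range from 27 mg/kg to 120 mg/kg.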

Compound 3, dose for half-maximal effect: 85.5 mg/kg
Compound 3: middle estimate off by 1.5-fold (0.17 log units), on the low side; measured number inside the range.
By their numbers in this assay, from the lowest: compound 2; then compounds 3 and 1 (each within the scatter of the next).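

In this assay, the methoxy on the aromatic carbon ortho to a large group turns out to matter: replacing it with hydrogen gives a 2.0-fold higher number from compound 2 to compound 3 (0.31 log units; beyond the scatter) and so takes compound 3 out of the range of compound 2, although the step is modest. The other single methoxy change on this ring does not have a comparable effect, since a 1.1-fold lower number from compound 1 to compound 3 (0.04 log units; within the scatter) leaves compound 1 and compound 3 within the scatter of each other, so among these three compounds only the methoxy present in compound 2 separates one compound from the rest. Nothing available explains why this one methoxy counts when the other does not.

The compounds shown leave open whether the methoxy itself is needed at this position or whether another group there, such as a fluorine, a hydroxyl or an amine, would hold the number of compound 2 just as well. They also leave open whether the same step would appear if the ester in the shared core were replaced by an amide.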